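Lipophilicity notes: replacing cyclohexyl in compound 2

A few compounds are considered here, and "the series" means these few. Any claim that something is new, unique, unknown or untested is made for them only; others in the source may bear on it.

- compound 1 `O=C(CN(C(=O)c1ccc(-n2ccnc2)cc1)C1CCCCC1)Nc1cc(F)cc(F)c1`: 2.7
- compound 2 `O=C(CN(C(=O)c1ccc(-c2ccccn2)cc1)C1CCCCC1)Nc1cc(F)cc(F)c1`: 3.7

In a physicochemical assay for lipophilicity (a lower number here means a more polar compound, a higher number a more lipophilic compound), compound 2 is the higher of the two measured compounds, at 3.7. The next step leads to compound 3 `O=C(CN(C(=O)c1ccc(-c2ccccn2)cc1)C1CCCOC1)Nc1cc(F)cc(F)c1`, which keeps the rest of compound 2 and has oxan-3-yl in place of cyclohexyl on an amide-type nitrogen.

Going by the values given here, only one measured step is available: a number 1.00 log units higher from compound 1 to compound 2 (beyond the scatter). It is a modest step beyond the scatter, but it involves a change on an aromatic carbon, not on the amide-type nitrogen. It therefore gives a rough sense of scale for a single-group swap in this series and no direct measure of the new change. Among the compounds with values here, no measured pair covers cyclohexyl and oxan-3-yl, so the expected direction rests on the structural change alone, with the added hydrogen-bond acceptor pointing to a lower number in this assay.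

The expected change is a number 1.10 log units lower from compound 2 to compound 3 (beyond the scatter), a decrease of modest size beyond the scatter. For compound 3 the estimated value is 2.6, with an expected range from 2.2 to 3.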

Compound 3, distribution coefficient: 2.7
Compound 3: middle estimate off by 0.10 log units, on the low side; the range from low to high includes it.
By their numbers in this assay, from the lowest: compounds 1 and 3 (each within the scatter of the next); then compound 2.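

Oxan-3-yl in place of cyclohexyl on an amide-type nitrogen gives, in this assay, a number 1.00 log units lower from compound 2 to compound 3 (beyond the scatter), the first measured step at this position, as the earlier pair differed only on an aromatic carbon. The two groups have the same count of 6 heavy atoms and each is a six-membered non-aromatic ring, with neither a hydrogen-bond donor nor a net charge; the differences are 1 oxygen in place of a carbon and 1 hydrogen-bond acceptor, and with these alone the number in this assay still moves beyond the scatter. No measurement shown here explains this step.

Going by these compounds, with a single replacement at this nitrogen, it remains open whether the step carries over to the core of compound 1, with 1H-imidazol-1-yl in place of pyridin-2-yl on the aromatic carbon. On these data alone, how this assay would read with oxan-4-yl, with an amine such as piperidin-4-yl, or with an open chain such as 2-methoxyethyl on the amide-type nitrogen also remains open.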